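Replacing a Benzyl Group by a Methoxyphenoxy Group

The source may report more compounds than this note shows. Statements on the series, on what has been measured and on what is new or still open speak of the compounds shown alone.

Of the compounds shown here, three of one shared core have been measured in an ADME assay for permeability, using PAMPA, with a stated time of 30 min, at pH 7.4; on this read-out higher numbers stand for higher permeability and lower numbers for lower permeability. Compound 1, `c1ccc(-c2ccc3c(NCCCNCc4ccco4)ccnc3c2)cc1`, gives 237 10^-6 cm/s in this assay. Compound 2, `COc1ccc(F)cc1CNCCCNc1ccnc2cc(CCC(C)C)ccc12`, gives 23 10^-6 cm/s, and compound 3, `COc1cccc(CNCCCNc2ccnc3cc(Cc4ccccc4)ccc23)c1O`, gives 23 10^-6 cm/s. Compound 3 thus stands level with compound 2 at the digits shown, and the two of them together sit at the low end of these three numbers, while compound 1 lies well beyond the scatter above both.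

Compound 4, `COc1cccc(Oc2ccc3c(NCCCNCc4cccc(OC)c4O)ccnc3c2)c1`, has not yet been measured in this assay. It differs from compound 3 in one place: 3-methoxyphenoxy in place of benzyl on an aromatic carbon. The side chain that compound 3 carries is kept unchanged in compound 4.

Nothing measured here shows directly what this kind of replacement does to permeability, so the expectation rests on the value of compound 3 alone, 23 10^-6 cm/s, and the step from it is expected to be a 1.1-fold higher number from compound 3 to compound 4 (0.04 log units; within the scatter), within the scatter. Compound 4 is therefore estimated at 25 10^-6 cm/s in this assay, within a range from 8 10^-6 cm/s to 70 10^-6 cm/s.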

Compound 4, apparent permeability: 317 10^-6 cm/s
Compound 4: the middle estimate sits 13-fold (1.10 log units) below what was measured, and the stated range ends below it.
By their numbers in this assay, from the lowest: compounds 2 and 3 (each within the scatter of the next); then compounds 1 and 4 (each within the scatter of the next).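

In this assay, placing 3-methoxyphenoxy instead of benzyl on this aromatic carbon gives a 14-fold higher number from compound 3 to compound 4 (1.14 log units; beyond the scatter), so the group held at this position can strongly change the read-out. The earlier compounds shown here could not show this, as no two of them differed in one place only, whereas here the side chain stays the same and the step belongs to this single replacement. The entering group brings two oxygen atoms and two hydrogen-bond acceptors, but no measurement here accounts for the size of the step.

From the compounds shown here alone, it remains open whether the linking oxygen, the methoxy group or both go with the step; a plain phenoxy group or a 3-methoxybenzyl group at this carbon would help separate them. Also open, going by these compounds, is how other groups, such as an amine or a longer chain, would behave here.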